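The compounds below may be only part of what the source reports. "The series", "measured", "known", "first", "only" and "open" are said of these compounds alone.

Measured compounds, tested in a functional assay on CCRF-CEM cells (Homo sapiens) for cytotoxicity, in the presence of a further agent that is not named here; on this read-out lower numbers stand for stronger inhibition and higher numbers for weaker inhibition:

- compound 1 `Nc1nc(N)c(CCCN(Cc2ccc(NC(CCC(=O)O)C(=O)O)cc2)c2cc(F)c([N+](=O)[O-])cc2[N+](=O)[O-])c(O)n1`: 43000 nM
- compound 2 `CC(C)(C)OC(=O)CCC(Nc1ccc(CN(CCCc2c(N)nc(N)nc2O)c2cc(F)cc(F)c2[N+](=O)[O-])cc1)C(=O)OC(C)(C)C`: 7700 nM

Of these two, compound 2 has the lower number at 7700 nM. Compound 1 reads higher at 43000 nM, and the gap between them lies beyond the scatter of repeated measurements. The two differ in more than one place, so their gap does not isolate any single structural change.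

The step followed here leads to compound 3 `CC(C)(C)OC(=O)CCC(Nc1ccc(CN(CCCc2c(N)nc(N)nc2O)c2cc(F)c(F)cc2[N+](=O)[O-])cc1)C(=O)OC(C)(C)C`, which has not yet been measured. It carries 4,5-difluoro-2-nitrophenyl in place of 3,5-difluoro-2-nitrophenyl on an amine nitrogen. The two compounds have the same atoms, joined differently. For the measured compounds named here, no measured pair shows what such a change does in this assay, so the data give no firm direction. The expectation is therefore no step beyond the scatter, with compound 3 staying close to compound 2 at 7700 nM. The estimated change is a 1.1-fold lower number from compound 2 to compound 3 (0.04 log units; within the scatter). In this assay, the estimate for compound 3 is 7000 nM, with an expected range from 2000 nM to 25000 nM.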

Compound 3, half-maximal inhibitory concentration: 3100 nM
Compound 3: the middle estimate sits 2.3-fold (0.35 log units) above what was measured; the range from low to high includes it.
By their numbers in this assay, from the lowest: compound 3; then compound 2; then compound 1.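

In this assay, putting 4,5-difluoro-2-nitrophenyl in place of 3,5-difluoro-2-nitrophenyl on the amine nitrogen gives a 2.5-fold lower number from compound 2 to compound 3 (0.40 log units; beyond the scatter), so this position responds to the arrangement of the groups on the ring even when the atoms stay the same. For the compounds shown here, the step is modest, but it is the first that can be read from a single change, and the two groups match in every count of atoms, rings, donors and acceptors, leaving the different joining of the same atoms as the only structural difference between compound 2 and compound 3. Nothing measured here bears on what lies behind the step.

Going by these compounds, compound 1 differs from compound 2 and compound 3 in more than one place, so its gaps to them cannot be read, and it remains open whether the same change would give a similar step with the free carboxylic acids of compound 1 in place of the tert-butyl esters. On these data alone, it also remains open how this position would respond to a chlorine atom or a methoxy group in place of either fluorine, or to a nitrile in place of the nitro group.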